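The source may report more compounds than this note shows. Statements on the series, on what has been measured and on what is new or still open speak of the compounds shown alone.

Two compounds of this series have numbers in a functional assay on HeLa cells (Homo sapiens) for cytotoxicity, read by MTT assay, with a stated time of 72 h, tested at 3 uM; a lower number here means less inhibition of growth, a higher number more inhibition of growth at the concentration tested. Compound 1 `N/C(=N\NC(=S)N1CCN(c2ccccn2)CC1)c1ccc(F)cn1` gives 77.3% and stands highest of the two; compound 2 `N/C(=N\NC(=S)N1CCCCCC1)c1ccccn1` gives 36.6%, a number lower by more than the scatter, and since the two structures differ in more than one place, nothing ties that gap to a single change. Compound 3 `N/C(=N\NC(=S)N1CCN(c2ccccn2)CC1)c1ccccn1` is not yet measured. Its difference from compound 1 is hydrogen in place of fluoro on an aromatic carbon. Among the compounds with values here, no measured pair shows this change on its own; a moderate loss is expected, and the step of a number 12.3 percentage points lower from compound 1 to compound 3 (beyond the scatter) is the estimate. For compound 3 the expected value is 65%, with a range from 45% to 82%.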

Compound 3, percent growth inhibition at one concentration: 24.4%
The estimate for compound 3 lay 40.6 percentage points above the measured number; the measured number lies below the stated range.
By their numbers in this assay, from the lowest: compound 3; then compound 2; then compound 1.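

In this assay, within the data shown here, the change from 5-fluoropyridin-2-yl to pyridin-2-yl gives the first single-change step, a number 52.9 percentage points lower from compound 1 to compound 3 (beyond the scatter), a large step. At this aromatic carbon, two atoms from the ring nitrogen, one fluorine atom therefore separates the high number of compound 1 from the low number of compound 3. Nothing available explains this step. Going by these compounds, whether chloro, methyl or methoxy at this carbon would match fluoro remains open. Also open, on these data alone, is whether the fluoro step recurs when the large group para to it is changed.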